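Hydroxycarbamoyl to hydroxy(methyl)carbamoyl: a next step

The source may report more compounds than this note shows. Statements on the series, on what has been measured and on what is new or still open speak of the compounds shown alone.

Going by the values given here, in a functional assay on MOLM-13 cells (Homo sapiens) for antiproliferative activity (a higher number here means a weaker inhibitor, a lower number a stronger inhibitor), compound 2 `Cc1c(-c2ccc(-c3ccccc3F)cc2)nc2ccc(F)cc2c1C(=O)NO` gives 23 nM, the only true number so far. Compound 1 `Cc1c(-c2ccc(-c3ccccc3F)cc2)nc2ccc(F)cc2c1-c1nnn[nH]1` gives > 3000 nM, which is a limit of the assay and not a number. Compound 3 `Cc1c(-c2ccc(-c3ccccc3F)cc2)nc2ccc(F)cc2c1C(=O)N(C)O` carries one change relative to compound 2: methyl in place of hydrogen on an amide-type nitrogen, with methyl in place of hydrogen on an amide-type nitrogen. Among the compounds with values here, the single measured step, an at least 130-fold lower number from compound 1 to compound 2 (2.11 log units; beyond the scatter), replaces the whole group and rests on a limit (the limit of > 3000 nM in this assay, at which 1 of the 2 values shown sits). It therefore bears only loosely on this smaller change, though it shows that this assay can respond strongly to the group carrying this nitrogen. A moderate move to a higher number, beyond the scatter, is expected, with wide uncertainty. The estimated step is a 6.5-fold higher number from compound 2 to compound 3 (0.81 log units; beyond the scatter). For compound 3 the expected value is 150 nM, with an estimated range of 25 nM to 1500 nM.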

Compound 3, half-maximal inhibitory concentration: 5100 nM
Estimate against measurement, compound 3: 34-fold (1.53 log units) below; measured number outside the range, above it.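

In this assay, methyl in place of hydrogen on the amide-type nitrogen, with the carbonyl carbon and oxygen kept, gives a 220-fold higher number from compound 2 to compound 3 (2.35 log units; beyond the scatter). The earlier step exchanged the whole group, whereas this one shows that keeping the hydroxycarbamoyl skeleton is not enough: in this pair, one added carbon on that nitrogen takes away most of the activity of compound 2. The step between compound 3 and compound 1 cannot be read because the value of compound 1 is a limit and not a number: the limit of > 3000 nM in this assay, at which 1 of the 3 values shown sits.

The compounds shown do not settle whether the effect belongs to the lost amide hydrogen or to the entering methyl, and a methoxycarbamoyl, a primary carboxamide or a carboxylic acid at this carbon would help separate these readings. As far as these compounds go, how ethyl on the same nitrogen would read also stays open.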